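The source may hold more compounds than are shown below. What is called first, only, known or untested is meant among the compounds shown, and "the series" means these compounds.

Measured compounds:
Compound 1, `C=CCOc1ccc2c(=O)c(-c3cc(OC)c(OC)cc3OC)coc2c1`: 5900 nM
Compound 2, `COc1cc(OC)c(-c2coc3cc(OCc4ccccc4)ccc3c2=O)cc1OC`: 6750 nM

In a functional assay on U-251 cells (Homo sapiens) for antiproliferative activity, read by MTT assay, with a stated time of 24 h (on this read-out higher numbers stand for weaker inhibition and lower numbers for stronger inhibition), compound 1 gives 5900 nM, and compound 2 gives 6750 nM; the two numbers stand level with each other, as the step of a 1.1-fold higher number from compound 1 to compound 2 (0.06 log units; within the scatter) shows. Compound 3, `COc1cc(OC)c(-c2coc3cc(OCc4cccc(C(F)(F)F)c4)ccc3c2=O)cc1OC`, has not yet been measured. It differs from compound 1 by 3-(trifluoromethyl)phenyl in place of vinyl on a saturated chain carbon bound to an oxygen on an aromatic ring. For the measured compounds named here, the one measured step that bears on this change is the one from compound 1 to compound 2, where a phenyl replaced the vinyl at the same place and the number hardly moved. Adding a trifluoromethyl to that phenyl is a further change for which no measured pair exists here, so nothing in the data points in either direction. The expected outcome is therefore a step of about a 1.1-fold higher number from compound 1 to compound 3 (0.04 log units; within the scatter), that is, none beyond the scatter. Compound 3 is estimated at 6500 nM, with a range from 3000 nM to 14000 nM.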

Compound 3, half-maximal inhibitory concentration: > 10000 nM
Compound 3 gave a limit, no number; the forecaster's own chance of this, stated with the estimate: 5%; middle value at least 1.5-fold (0.18 log units) from the limit.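

In this assay compound 3 gives > 10000 nM, which is a limit of the assay and not a number: the limit of > 10000 nM in this assay, at which 1 of the 3 values shown sits.

Read as floors, the steps are an at least 1.6-fold higher number from compound 1 to compound 3 (0.22 log units; that floor lies within the scatter) and an at least 1.4-fold higher number from compound 2 to compound 3 (0.17 log units; that floor lies within the scatter). Unlike the swap of vinyl for phenyl, adding a trifluoromethyl to that phenyl leaves the true number without an upper end, so this change could mean a large loss of inhibition or almost none, and neither floor alone establishes a real loss.

The compounds shown leave open how far the number for compound 3 lies past the limit. They also leave open how this assay would read with an amine or a carboxylic acid on the benzyl group, or with a longer chain in place of the allyl.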